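Rearranging the Pentyl Chain of Compound 3

The source may report more compounds than this note shows. Statements on the series, on what has been measured and on what is new or still open speak of the compounds shown alone.

Three related compounds have been measured so far. In a physicochemical assay for lipophilicity (a lower number here means a more polar compound, a higher number a more lipophilic compound), compound 1 `Brc1ccc(N(CC2CC2)C2=NCCN2)c(Br)c1` gives -0.31. Compound 2 `CCCCN(C1=NCCN1)c1c(Br)cccc1Br` gives -2.5. Compound 3 `CCCCCN(C1=NCCN1)c1c(Br)cccc1Br` gives 0.32, the highest of the three numbers and beyond the usual scatter of both others.

The next compound, compound 4 `CC(C)CCN(C1=NCCN1)c1c(Br)cccc1Br`, has the same atoms as compound 3, joined differently: isopropyl in place of propyl on a saturated chain carbon, two bonds along the chain from a nitrogen on an aromatic ring. In words, isopropyl stands in place of propyl on a saturated chain carbon, two bonds along the chain from a nitrogen on an aromatic ring. Cut one bond further out, the same difference reads pentyl to isopentyl.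

For the measured compounds named here, only one measured step bears on this change. Methyl in place of hydrogen on a saturated chain carbon gives a number 2.82 log units higher from compound 2 to compound 3 (beyond the scatter). Going by the values given here, that step adds a carbon, whereas the new change adds none, and no measured pair sets a branched chain against a straight one. Its large size is still a warning that a modest edit to this chain can move the number far, which calls for a wide range.

In this assay, no step beyond the scatter is expected, and the estimate is a number 0.17 log units lower from compound 3 to compound 4 (within the scatter). For compound 4 the estimated value is 0.15, with an expected range from -0.6 to 0.85.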

Compound 4, distribution coefficient: 0.16
Compound 4: the middle estimate sits 0.01 log units below what was measured; the range from low to high includes it.
By their numbers in this assay, from the lowest: compound 2; then compound 1; then compounds 4 and 3 (each within the scatter of the next).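

In this assay, for the compounds shown here, the first comparison of a branched chain with a straight one gives a number 0.16 log units lower from compound 3 to compound 4 (within the scatter) and so leaves compound 3 and compound 4 not distinguishable: at this position, rearranging the same carbons from pentyl to isopentyl does not move the number beyond the scatter. Placing the added carbon as a methyl on a saturated chain carbon bound to two saturated chain carbons gives a number 2.66 log units higher from compound 2 to compound 4 (beyond the scatter) as its result, a large step much like a number 2.82 log units higher from compound 2 to compound 3 (beyond the scatter) for the straight chain, so in these compounds the jump from the butyl chain appears with either ending. Going by these compounds alone, nothing measured here explains why one added carbon moves the number so far while rearranging the carbons does not.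

Still open, from the compounds shown here alone, is whether a longer chain such as hexyl would raise the number further or whether the rise stops at these pentyl and isopentyl chains. Also open, going by these compounds, is how far the number would move with an amine or a carboxylic acid on the chain, since every chain compared in one place here is made of carbon alone.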